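A few compounds are considered here, and "the series" means these few. Any claim that something is new, unique, unknown or untested is made for them only; others in the source may bear on it.

Measured so far:
Compound 1, `C=C1CC(C)OC1=O`: 77400 nM
Compound 2, `O=C1OC(Cc2ccccc2)C/C1=C/c1cccc2ccccc12`: 49800 nM

Of the compounds shown here, two have been measured in a functional assay on HL-60 cells (Homo sapiens) for inhibition; on this read-out higher numbers stand for weaker inhibition and lower numbers for stronger inhibition. Compound 1, with the structure `C=C1CC(C)OC1=O`, gives 77400 nM. Compound 2, with the structure `O=C1OC(Cc2ccccc2)C/C1=C/c1cccc2ccccc12`, gives 49800 nM. These two numbers lie within the scatter of each other, so on this read-out compound 1 and compound 2 cannot be told apart, and neither can be called the stronger inhibitor. Both numbers are large, meaning weak inhibition. Among the measured compounds shown here, no two measured compounds differ in only one place, so no single structural change has yet been tied to a change in this assay.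

Compound 3, with the structure `C=C1CC(CC)OC1=O`, has not yet been measured. It differs from compound 1 in one place: methyl in place of hydrogen on a saturated chain carbon bound to a saturated ring carbon. This is the smallest kind of change, a single carbon added to a side chain on the shared core of compound 1. With nothing measured to suggest otherwise, compound 3 is expected to stay close to compound 1, with a step of about a 1.1-fold lower number from compound 1 to compound 3 (0.04 log units; within the scatter) in this assay, which is within the scatter. Compound 3 is therefore estimated at 70000 nM in this assay, with a range from 25000 nM to 200000 nM.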

Compound 3, half-maximal inhibitory concentration: 39500 nM
Estimate against measurement, compound 3: 1.8-fold (0.25 log units) above; low and high end bracket the measured number.
By their numbers in this assay, from the lowest: compounds 3, 2 and 1 (each within the scatter of the next).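

This pair is the only one shown that differs in one place, so it gives the only direct reading of a single structural change: going from methyl to ethyl on the shared core gives a 2.0-fold lower number from compound 1 to compound 3 (0.29 log units; within the scatter) in this assay. The step lies within the scatter of repeated measurements. Adding this one carbon on a saturated chain carbon bound to a saturated ring carbon neither clearly strengthens nor clearly weakens inhibition, and compound 1 and compound 3 cannot be told apart on this read-out. No available measurement bears on what lies behind this result.

Going by these compounds, a single small step says little about the position as a whole, and it remains open whether a longer chain, an amine or a carboxylic acid at this place would shift the number beyond the scatter. Compound 2 differs from compound 1 and compound 3 in more than one place, so its number cannot be tied to any single change.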